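Sulfonyl cap in place of carbonyl cap on the shared core

A few compounds are considered here, and "the series" means these few. Any claim that something is new, unique, unknown or untested is made for them only; others in the source may bear on it.

Compound 1 `CCCCCCCCCCCCCCCCCCNC(=O)[C@@H](NC(=O)c1cc2ccccc2n1C)[C@@H](C)O` gives 36400 nM in a functional assay on MCF7 cells (Homo sapiens) for cytotoxicity, read by MTT assay, with a stated time of 48 h; a lower number here means a stronger inhibitor, a higher number a weaker inhibitor. Compound 2 `CCCCCCCCCCCCCCCCCCNC(=O)[C@@H](NC(=O)/C=C/c1ccccc1)[C@@H](C)O` gives 39200 nM in this assay, and the step of a 1.1-fold higher number from compound 1 to compound 2 (0.03 log units; within the scatter) shows that swapping one aromatic carbonyl group for another left the number where it was. On the two numbers shown, compound 2 stands highest, with compound 1 nearest and within the scatter of it, so no order between the two can be claimed.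

Compound 3 `CCCCCCCCCCCCCCCCCCNC(=O)[C@@H](NS(=O)(=O)c1cccs1)[C@@H](C)O` is not yet measured. It differs from compound 2 by (thiophen-2-yl)sulfonyl in place of (2-phenylethenyl)carbonyl on an amine nitrogen. Going by the values given here, the only measured step, a 1.1-fold higher number from compound 1 to compound 2 (0.03 log units; within the scatter), changed the aryl part while keeping the carbonyl, and was within the scatter; no measured step exchanges a carbonyl for a sulfonyl, so the data bear on this change only loosely. The expectation is therefore no step beyond the scatter, a 1.0-fold higher number from compound 2 to compound 3 (0.01 log units; within the scatter). For compound 3 the estimate in this assay is 40000 nM, with a range from 15000 nM to 100000 nM.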

Compound 3, half-maximal inhibitory concentration: > 200000 nM
Compound 3 gave a limit, no number (the forecaster's own chance of this, stated with the estimate: 25%); middle value at least 5.0-fold (0.69 log units) from the limit.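

In this assay, compound 3 gives a limit of the assay and not a number: the limit of > 200000 nM in this assay, at which 1 of the 3 values shown sits.

Placing (thiophen-2-yl)sulfonyl on the amine nitrogen gives an at least 5.1-fold higher number from compound 2 to compound 3 (0.70 log units; beyond the scatter) and an at least 5.4-fold higher number from compound 1 to compound 3 (0.73 log units; beyond the scatter), and both are lower bounds on the size of the step, whereas the aryl change with the carbonyl kept stayed within the scatter. This position is therefore not indifferent to the group it carries, which compound 1 and compound 2 alone could not show.

The compounds shown do not separate the sulfonyl from the thiophene ring, since both enter together; a (thiophen-2-yl)carbonyl or a phenylsulfonyl group would divide the step between them. On these data alone, the true size of the step also stays open, as does whether it holds with a shorter chain in place of the long alkyl chain.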